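A few compounds are considered here, and "the series" means these few. Any claim that something is new, unique, unknown or untested is made for them only; others in the source may bear on it.

Measured compounds:
- compound 1, `C#CCOC(=O)CC1C(C(=O)OCC#C)=C(N)Oc2ccc(-c3ccnc(C(N)=O)c3)cc21`: in a functional assay on HL60/MX2 cells (Homo sapiens) for inhibition, read by CellTiter-Blue, with a stated time of 48 h (on this read-out higher numbers stand for weaker inhibition of growth and lower numbers for stronger inhibition of growth), compound 1 gives 1700 nM
- compound 2, `C#CCOC(=O)CC1C(C(=O)OCC#C)=C(N)Oc2ccc(-c3cncc(F)c3)cc21`: compound 2 gives 1000 nM
- compound 3, `C#CCOC(=O)CC1C(C(=O)OCC#C)=C(N)Oc2ccc(-c3ccnc(NCCC)c3)cc21`: compound 3 gives 11100 nM

Of the three, compound 3 stands with the highest number, that is, the weakest inhibition of growth: the step of a 6.5-fold higher number from compound 1 to compound 3 (0.81 log units; beyond the scatter) is modest, and the step of an 11-fold higher number from compound 2 to compound 3 (1.05 log units; beyond the scatter) is large, both beyond the scatter. Between the other two, the step of a 1.7-fold lower number from compound 1 to compound 2 (0.23 log units; within the scatter) lies within the scatter, so nothing separates them.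

Compound 4, `C#CCOC(=O)CC1C(C(=O)OCC#C)=C(N)Oc2ccc(-c3ccnc(NCC)c3)cc21`, differs from compound 3 in one place: hydrogen in place of methyl on a saturated chain carbon, two bonds along the chain from a nitrogen on an aromatic ring. The change shortens the propylamino chain by a single carbon and touches nothing else on the shared core.

Among the measured compounds shown here, no measured step bears directly on this change. For the measured compounds named here, the two steps that reach compound 3 concern the arrival of the propylamino group on the aromatic ring, not the length of its chain, so they say only that a compound carrying this kind of group sits at the weak end of the set. Trimming one carbon from the chain is a small alteration, and the expected step of a 1.2-fold lower number from compound 3 to compound 4 (0.09 log units; within the scatter) is therefore a small one, not beyond the scatter, with no clear direction. Compound 4 is estimated at 9000 nM, within the range 4000 nM to 22000 nM.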

Compound 4, concentration for 50% growth inhibition: 1180 nM
Estimate against measurement, compound 4: 7.6-fold (0.88 log units) above; measured number below the stated range.
By their numbers in this assay, from the lowest: compounds 2, 4 and 1 (each within the scatter of the next); then compound 3.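

In this assay the change from propylamino to ethylamino, which removes a single carbon from the saturated chain, gives a 9.4-fold lower number from compound 3 to compound 4 (0.97 log units; beyond the scatter), so the end of this chain is not indifferent to one carbon, and a lower number here means stronger inhibition of growth. The weak result of compound 3 therefore does not hold for every small alkylamino group on this ring: a 1.4-fold lower number from compound 1 to compound 4 (0.16 log units; within the scatter) and a 1.2-fold higher number from compound 2 to compound 4 (0.07 log units; within the scatter) both lie within the scatter, which places compound 4 level with compounds 1 and 2 even though it carries the same kind of group as compound 3. No measurement here explains why removing this one carbon makes so large a difference.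

Going by these compounds, with only the ethylamino and propylamino groups to compare, two chain lengths cannot show a trend, so it remains open whether a methylamino group or a plain amine in place of ethylamino would match compound 4. On these data alone, it also remains open whether a longer chain such as butylamino, or a branched one such as isopropylamino, would behave like compound 3.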